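The compounds below may be only part of what the source reports. "The series", "measured", "known", "first", "only" and "open" are said of these compounds alone.

Compound 1 `CC[C@]1(C(=O)O)CC[C@H](C(=O)N2CC[C@](c3ccc(C(F)(C(F)(F)F)C(F)(F)F)cc3)(S(=O)(=O)c3ccc(F)cc3)C2)CC1` is examined in an ADME assay on microsomes from liver (Homo sapiens) for metabolic stability, with a stated time of 10 min; on this read-out higher numbers stand for a more stable compound and lower numbers for a less stable compound. In this assay compound 1 gives 100%. For the measured compounds named here, only one other compound has a number here. Compound 3 `O=C(O)C12CCC(C(=O)N3CC[C@](c4ccc(C(F)(C(F)(F)F)C(F)(F)F)cc4)(S(=O)(=O)c4ccc(F)cc4)C3)(CC1)OC2` differs from compound 1 only in the group attached to the carbonyl carbon. In this assay compound 3 gives 90%, and the step of a number 10 percentage points lower from compound 1 to compound 3 (within the scatter) lies within the scatter, so the two compounds cannot be told apart on this read-out. Compound 2 `CCC[C@]1(C(=O)N2CC[C@](c3ccc(C(F)(C(F)(F)F)C(F)(F)F)cc3)(S(=O)(=O)c3ccc(F)cc3)C2)CC[C@H](C(=O)O)CC1` belongs to the same series, but in this assay compound 2 has "not determined" (no result reported), so no number is available for it.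

Compound 4 `O=C([C@H]1CC[C@H](c2nnn[nH]2)CC1)N1CC[C@](c2ccc(C(F)(C(F)(F)F)C(F)(F)F)cc2)(S(=O)(=O)c2ccc(F)cc2)C1` has not yet been measured. Compared with compound 1, the change is 4-(1H-tetrazol-5-yl)cyclohexyl in place of 4-carboxy-4-ethylcyclohexyl on a carbonyl carbon. Going by the values given here, the only measured step that bears on this is the one from compound 1 to compound 3, which also swaps the whole group on that carbonyl carbon for another of the same size, and that step stayed within the scatter. Among the compounds with values here, no measured pair exchanges the carboxy group itself, so the data give no direct guide for the tetrazole. On that basis compound 4 is expected to stay close to compound 1, with an estimated step of a number 10 percentage points lower from compound 1 to compound 4 (within the scatter) in this assay. The estimate for compound 4 is 90%, within a range from 70% to 100%.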

Compound 4, percent of the compound remaining: 100%
The estimate for compound 4 lay 10 percentage points below the measured number, within the range that was stated.
By their numbers in this assay, from the lowest: compounds 3, 1 and 4 (each within the scatter of the next).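

In this assay, the group on the carbonyl carbon can give up its carboxylic acid without a readable effect: the step is no change at the digits printed from compound 1 to compound 4 (within the scatter), even though the exchange removes the ethyl group as well and brings in a tetrazole. Compound 1 and compound 3 both carry a carboxylic acid, so they showed only that the rest of this group can vary, whereas compound 4 extends that to the carboxylic acid itself, and the step of a number 10 percentage points higher from compound 3 to compound 4 (within the scatter) likewise stays inside the usual scatter. All three groups at this place therefore read alike on this measure, and no measurement here explains why.

Going by these compounds, the tetrazole and the loss of the ethyl group arrive together, so the share of each in this result stays unknown, and a compound with the ethyl group and the tetrazole on the same ring carbon would be needed to separate them. Also open, on these data alone, is whether a cyclohexyl group bearing an amine, a primary amide or a nitrile in place of the tetrazole would read the same way.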